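Propargylamine for carbamoylethylamine across two chain lengths

A few compounds are considered here, and "the series" means these few. Any claim that something is new, unique, unknown or untested is made for them only; others in the source may bear on it.

Measured so far, in an assay on BTI cells for inhibition of Amine oxidase [flavin-containing] B (Homo sapiens), read by fluorescence, with stated times of 30 min and 1 h; a higher number here means a weaker inhibitor, a lower number a stronger inhibitor:
compound 1 `C[C@H](NCc1ccc(OCCCCCN2CCN(c3cccc4c3ccn4Cc3cccc(Cl)c3)CC2)cc1)C(N)=O`, compound 1 gives > 1000 nM
compound 2 `C[C@H](NCc1ccc(OCCCCCCN2CCN(c3cccc4c3ccn4Cc3cccc(Cl)c3)CC2)cc1)C(N)=O`, compound 2 gives > 1000 nM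
compound 3 `C#CCN(C)Cc1ccc(OCCCCCN2CCN(c3cccc4c3ccn4Cc3cccc(Cl)c3)CC2)cc1`, compound 3 gives 30 nM

The value of compound 1 is a limit of this assay, not a number. The value of compound 2 is likewise a limit. How the core of compound 1 differs from the core of compound 2 is not broken down here.

Within the core of compound 1, the change methyl(propargyl)amino in place of (1-carbamoylethyl)amino on a saturated chain carbon bound to an aromatic carbon gives an at least 33-fold lower number from compound 1 to compound 3 (1.52 log units; beyond the scatter). Compound 3 is the only one of the three with a numerical value; the other two sit at the limit of > 1000 nM in this assay, at which 2 of the 3 values shown sit.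

Compound 4 `C#CCN(C)Cc1ccc(OCCCCCCN2CCN(c3cccc4c3ccn4Cc3cccc(Cl)c3)CC2)cc1` is not yet measured. It carries the same change on the core of compound 2: methyl(propargyl)amino in place of (1-carbamoylethyl)amino on a saturated chain carbon bound to an aromatic carbon. Both changes sit on a saturated chain carbon bound to an aromatic carbon, so this is the same change. Taking compound 3 and its 30 nM as the only numerical anchor, compound 4 is expected to show a step of about an at least 25-fold lower number from compound 2 to compound 4 (1.39 log units; beyond the scatter) in this assay. Compound 4 is estimated at 40 nM, between 10 nM and 200 nM.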

Compound 4, half-maximal inhibitory concentration: > 1000 nM
Compound 4: a limit, no number; the forecaster's own chance of this, stated with the estimate: 5%; middle value at least 25-fold (1.39 log units) away from the limit.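

In this assay compound 4 gives > 1000 nM, which is a limit and not a number. Within the data shown here, compound 2 also stands at a limit, so no step between compound 2 and compound 4 can be read: the limit of > 1000 nM in this assay, at which 3 of the 4 values shown sit. The compounds shown leave open whether methyl(propargyl)amino in place of (1-carbamoylethyl)amino changes the read-out at all on the core of compound 2.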